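The compounds below may be only part of what the source reports. "The series", "measured", "known", "first", "only" and "open" are said of these compounds alone.

Measured compounds and values in a functional assay on SW1573 cells (Homo sapiens) for inhibition, read by sulforhodamine B assay, with a stated time of 48 h; a lower number here means a stronger inhibitor of growth, a higher number a weaker inhibitor of growth:
- compound 1 `COC(=O)[C@@]1(C)CCC=C2[C@@H]1CC[C@@H](C)[C@]2(C)Cc1c[nH]c2ccccc12` gives 7300 nM
- compound 2 `COC(=O)[C@@]1(C)CCC=C2[C@@H]1CC[C@@H](C)[C@]2(C)Cc1c[nH]c2ccc(C(F)(F)F)cc12` gives 14000 nM
- compound 3 `COC(=O)[C@@]1(C)CCC=C2[C@@H]1CC[C@@H](C)[C@]2(C)Cc1c(C)[nH]c2ccccc12` gives 14000 nM

Compound 3 stands level with compound 2 at the digits read out, the two of them together the highest of the three numbers; its nearest neighbour is compound 2, its furthest compound 1, and the gap to compound 1 is within the scatter.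

The change from compound 3 to compound 4 `COC(=O)[C@@]1(C)CCC=C2[C@@H]1CC[C@@H](C)[C@]2(C)Cc1c(C)[nH]c2ccc(Br)cc12` is bromo in place of hydrogen on an aromatic carbon. Of the steps that have been measured, the one that bears most directly on it is the substitution on the same six-membered aromatic ring: a 1.9-fold higher number from compound 1 to compound 2 (0.28 log units; within the scatter). Going by the values given here, the other step, a 1.9-fold higher number from compound 1 to compound 3 (0.28 log units; within the scatter), concerns a different position and only shows that the series so far moves little. Taken together, no step beyond the scatter is expected in this assay for the bromo substitution; if anything a slightly higher number, in line with the trifluoromethyl step. Compound 4 is therefore expected to give about 18000 nM, within a range of 7000 nM to 45000 nM, which means an expected step of a 1.3-fold higher number from compound 3 to compound 4 (0.11 log units; within the scatter).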

Compound 4, concentration for 50% growth inhibition: 14000 nM
For compound 4 the middle estimate is 1.3-fold (0.11 log units) above the measured one, and the stated range covers the measured number.
By their numbers in this assay, from the lowest: compounds 1, 2, 3 and 4 (each within the scatter of the next).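

In this assay, bromo in place of hydrogen on an aromatic carbon, meta to a fused ring and para to a fused ring, gives no change at the digits printed from compound 3 to compound 4 (within the scatter) on the methyl-bearing core. Until now, the only substitution on this six-membered ring was trifluoromethyl on the core without the methyl, with a 1.9-fold higher number from compound 1 to compound 2 (0.28 log units; within the scatter) as its step, so this place now carries a second group, again with a step within the scatter. No measurement here bears on why this substitution leaves the number unchanged.

On these data alone, with only bromo and trifluoromethyl at this carbon, it stays open whether an amine or a carboxylic acid there would give a step beyond the scatter. Also open, as far as these compounds go, is whether a longer chain in place of the methyl would do so.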